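A Methoxy Ring Swap on Compound 1

The compounds below may be only part of what the source reports. "The series", "measured", "known", "first", "only" and "open" are said of these compounds alone.

In an ADME assay on microsomes from liver (Rattus norvegicus) for metabolic stability (a higher number here means that the compound lasts longer, a lower number that the compound disappears faster), compound 1 `COc1cc(OCc2cccc(-c3cnc(OC)nc3)c2)c2cc(-c3cn4nc(OC)sc4n3)oc2c1` gives 1.03 h as the higher of two exact numbers, while compound 2 `COc1cc(OCc2csc(-c3ccc(C(N)=O)cc3)n2)c2cc(-c3cn4nc(OC)sc4n3)oc2c1` gives 0.4 h in the same read-out. Compound 3 `COc1cc(OCc2csc(-c3ccc(C(=O)O)cc3)n2)c2cc(-c3cn4nc(OC)sc4n3)oc2c1` stands at > 2 h as a limit and not a number. Compound 4 `COc1ccc(-c2cccc(COc3cc(OC)cc4oc(-c5cn6nc(OC)sc6n5)cc34)c2)nc1` differs from compound 1 by 5-methoxypyridin-2-yl in place of 2-methoxypyrimidin-5-yl on an aromatic carbon and by nothing else. Among the compounds with values here, the only measured step of an at least 5.0-fold higher number from compound 2 to compound 3 (0.69 log units; beyond the scatter) puts hydroxy in place of amino on a carbonyl carbon, and it does not touch this group. In this assay the expected step of a 1.1-fold lower number from compound 1 to compound 4 (0.06 log units; within the scatter) therefore stays within the scatter. Compound 4 is estimated at 0.9 h (expected range 0.4 h to 2 h).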

Compound 4, half-life: 0.317 h
Beside the measured number, compound 4's estimate is 2.8-fold (0.45 log units) above it; the measured number lies below the stated range.
By their numbers in this assay, from the lowest: compounds 4 and 2 (each within the scatter of the next); then compound 1. At a limit, above all of these: compound 3.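

On the aromatic carbon meta to a large group, this exchange of rings is not neutral in this assay: 5-methoxypyridin-2-yl in place of 2-methoxypyrimidin-5-yl gives a 3.2-fold lower number from compound 1 to compound 4 (0.51 log units; beyond the scatter). The entering ring has the same count of heavy atoms, but one hetero atom and one hydrogen-bond acceptor fewer. Nothing measured here accounts for this step.

From the compounds shown here alone, it remains open whether the step follows from the lost ring nitrogen or from the different arrangement of the ring. Going by these compounds, how an amine in place of the methoxy group would behave on either ring also remains open.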